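From compound 3 to compound 4: expected step

The source may hold more compounds than are shown below. What is called first, only, known or untested is meant among the compounds shown, and "the series" means these compounds.

In an ADME assay on microsomes from liver (Homo sapiens) for metabolic stability, read by LC-MS, using NADPH, with stated times of 5 min and 30 min, tested at 1 uM (on this read-out lower numbers stand for slow clearance and higher numbers for fast clearance), compound 1 `Fc1ccc2c(c1CNc1ncc(Oc3ccccc3)c3nncn13)CCO2` gives 18 mL.min-1.g-1 and compound 3 `CC1(C)CC(=O)N(c2cnc(NCc3c(F)ccc4c3CCO4)n3cnnc23)C1` gives 16 mL.min-1.g-1 as a matching pair, with a 1.1-fold lower number from compound 1 to compound 3 (0.05 log units; within the scatter) inside the scatter. For compound 2 `COCCC(=O)Nc1cnc(NCc2c(F)ccc3c2CCO3)n2cnnc12` the read-out is only a limit of < 3 mL.min-1.g-1 and not a number. Compound 3 therefore stands level with compound 1, and an at least 5.3-fold higher number from compound 2 to compound 3 (0.72 log units; beyond the scatter) separates it from compound 2.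

Compound 4 `CN(c1ccccc1)c1cnc(NCc2c(F)ccc3c2CCO3)n2cnnc12` carries methyl(phenyl)amino in place of 4,4-dimethyl-2-oxopyrrolidin-1-yl on an aromatic carbon and keeps the rest of the core. Compound 1 is the nearest guide, since its phenoxy also brings a six-membered aromatic ring of carbon only, and its exchange for the group of compound 3 gave a 1.1-fold lower number from compound 1 to compound 3 (0.05 log units; within the scatter) without a shift beyond the scatter. Among the compounds with values here, the one large change, an at least 6.0-fold lower number from compound 1 to compound 2 (0.77 log units; beyond the scatter), came with ((2-methoxyethyl)carbonyl)amino, which compound 4 lacks. The expected size is a 1.4-fold higher number from compound 3 to compound 4 (0.14 log units; within the scatter) so no step beyond the scatter is expected in this assay for this exchange. Estimated for compound 4: 22 mL.min-1.g-1 (expected range 9 mL.min-1.g-1 to 55 mL.min-1.g-1).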

Compound 4, intrinsic clearance in microsomes in the Homo sapiens assay: 55 mL.min-1.g-1
For compound 4 the middle estimate is 2.5-fold (0.40 log units) below the measured one; the measured number falls inside the stated range.
By their numbers in the Homo sapiens assay, from the lowest: compounds 3 and 1 (each within the scatter of the next); then compound 4. At a limit, below all of these: compound 2.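

In the Homo sapiens assay, methyl(phenyl)amino on this aromatic carbon moves the read-out beyond the scatter, with a 3.4-fold higher number from compound 3 to compound 4 (0.54 log units; beyond the scatter) and a 3.1-fold higher number from compound 1 to compound 4 (0.49 log units; beyond the scatter), so phenoxy and methyl(phenyl)amino are not interchangeable here despite sharing a six-membered aromatic ring of carbon only. The range at this position also widens, with an at least 18-fold higher number from compound 2 to compound 4 (1.26 log units; beyond the scatter), a step read against the limit for compound 2. In a physicochemical assay for solubility, read by LC-MS, in phosphate buffer, with a stated time of 24 h, at pH 7.4 (a lower number here means a less soluble compound, a higher number a more soluble compound), compound 3 gives 57000 nM. In the physicochemical assay compound 4 gives only a limit and not a number, < 2000 nM. In the physicochemical assay the exchange of 4,4-dimethyl-2-oxopyrrolidin-1-yl for methyl(phenyl)amino brings an at least 28-fold lower number from compound 3 to compound 4 (1.45 log units; beyond the scatter), read against this limit: the limit of < 2000 nM in the physicochemical assay, at which 1 of the 2 values shown sits.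

Open, on these data alone, is whether a phenylamino group, without the methyl, would read like compound 4 or like compound 1 in the Homo sapiens assay. Also open, as far as these compounds go, is whether a morpholin-4-yl group at this position would give a low number in the Homo sapiens assay together with a high number in the physicochemical assay.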